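Notes on replacing a methoxy group in compound 2

The compounds below may be only part of what the source reports. "The series", "measured", "known", "first", "only" and "open" are said of these compounds alone.

Measured in a functional assay on DU-145 cells (Homo sapiens) for cytotoxicity, read by MTT assay, with a stated time of 48 h; on this read-out higher numbers stand for weaker inhibition and lower numbers for stronger inhibition:
- compound 1 `COc1ccc(/C=C/c2cc(OC)c(OC)c(OC)c2-c2ccc(OC)cc2)cc1`: 34000 nM
- compound 2 `C=C(c1ccc(OC)cc1)c1cc(OC)c(OC)c(OC)c1-c1ccc(OC)cc1`: 37000 nM

Compound 2 stands level with compound 1, the gap lying within the scatter: a 1.1-fold higher number from compound 1 to compound 2 (0.04 log units; within the scatter). Compound 3 `C=C(c1ccc(OC)cc1)c1cc(OC)c(OC)c(OC)c1-c1ccccc1` has hydrogen in place of methoxy on an aromatic carbon, para to a large group, reading 4-methoxyphenyl to phenyl: hydrogen in place of methoxy on an aromatic carbon. Going by the values given here, the one measured step exchanges 2-(4-methoxyphenyl)ethenyl for 1-(4-methoxyphenyl)ethenyl, so it does not test this change, and no measured pair does. Going by these compounds, the direction therefore stays open, and no shift beyond the scatter is expected in this assay. The expected step is a 1.2-fold lower number from compound 2 to compound 3 (0.09 log units; within the scatter). Compound 3 is estimated at 30000 nM, with an expected range of 10000 nM to 70000 nM.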

Compound 3, half-maximal inhibitory concentration: 8000 nM
For compound 3 the middle estimate is 3.8-fold (0.57 log units) above the measured one; the whole stated range lies above it.
By their numbers in this assay, from the lowest: compound 3; then compounds 1 and 2 (each within the scatter of the next).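

Hydrogen in place of methoxy on an aromatic carbon, para to a large group, is the only change shown that moves the number beyond the scatter: in this assay the change from 4-methoxyphenyl to phenyl gives a 4.6-fold lower number from compound 2 to compound 3 (0.67 log units; beyond the scatter) and so stronger inhibition. This position therefore responds to substitution, and methoxy is not required here for activity. Nothing available bears on the reason for this step.

Going by these compounds, whether a hydroxyl group, fluorine or an amine at this position would give a different reading remains open. Also open, on these data alone, is whether the same gain holds with the 2-(4-methoxyphenyl)ethenyl group of compound 1.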